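A ring swap on compound 2

The compounds below may be only part of what the source reports. "The series", "measured", "known", "first", "only" and "open" are said of these compounds alone.

Of the compounds shown here, two have been measured so far in a physicochemical assay for solubility, in phosphate buffer, at pH 6.8; on this read-out lower numbers stand for lower solubility and higher numbers for higher solubility. Compound 1 `COc1ccc(C(=O)C2=C(O)C(=O)N(c3ccc(-c4ccon4)cc3)C2c2ccccc2OC)cc1` gives a real number, 34700 nM. Compound 2 `Cc1nc(-c2ccc(N3C(=O)C(O)=C(C(=O)C(C)(C)C)C3c3ccccc3OCCO)cc2)no1` is reported as > 50000 nM, which is a limit of the assay and not a number. On these data alone, the data so far therefore contain (the limit of > 50000 nM in this assay, at which 1 of the 2 values shown sits), and the true position of compound 2 remains unknown.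

Compound 3 `CC(C)(C)C(=O)C1=C(O)C(=O)N(c2ccc(-c3ccsc3)cc2)C1c1ccccc1OCCO` keeps the rest of compound 2 and changes one group: thiophen-3-yl in place of 5-methyl-1,2,4-oxadiazol-3-yl on an aromatic carbon. For the measured compounds named here, no measured pair of compounds isolates this swap, so any forecast is rough. Going by the values given here, compound 1, at 34700 nM, offers the only firm number, and it differs from compound 3 in more than one place.

A downward move beyond the usual scatter is expected in this assay, with an estimated at least 2.5-fold lower number from compound 2 to compound 3 (0.39 log units; beyond the scatter). Compound 3 is expected to read about 20000 nM, with an estimated range from 5000 nM to 50000 nM.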

Compound 3, solubility: > 50000 nM
Compound 3: only a limit was reported; the forecaster's own chance of this, stated with the estimate: 20%; middle value at least 2.5-fold (0.39 log units) from the limit.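

In this assay compound 3 gives > 50000 nM as its reading, a limit of the assay and not a number. No step from compound 2 to compound 3 can be read, because both stand at a limit: the limit of > 50000 nM in this assay, at which 2 of the 3 values shown sit.

The compounds shown leave open whether thiophen-3-yl in place of 5-methyl-1,2,4-oxadiazol-3-yl shifts the true reading at all, and in which direction.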